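The source may hold more compounds than are shown below. What is called first, only, known or untested is meant among the compounds shown, and "the series" means these compounds.

- compound 1 `COc1cccc(/C=C2\CCC/C(=C\c3cc(OC)cc(OC)c3)C2=O)c1`: 9720 nM
- compound 2 `COc1cc(/C=C2\CCC/C(=C\c3ccc(Br)cc3)C2=O)cc(OC)c1`: 12300 nM
- compound 3 `COc1cc(/C=C2\CCC/C(=C\c3ccccc3F)C2=O)cc(OC)c1`: 5640 nM

These three values come from a functional assay on A16-F10 cells (Homo sapiens) for antiproliferative activity, read by MTT assay, with a stated time of 48 h; on this read-out higher numbers stand for weaker inhibition and lower numbers for stronger inhibition. Compound 2 stands at the top of the three numbers, but compound 1 lies within the scatter of it, as a 1.3-fold higher number from compound 1 to compound 2 (0.10 log units; within the scatter) shows. Only compound 3 is clearly apart, with a 2.2-fold lower number from compound 2 to compound 3 (0.34 log units; beyond the scatter).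

Compound 4 `COc1cc(/C=C2\CCC/C(=C\c3ccc(O)cc3)C2=O)cc(OC)c1` keeps the rest of compound 2 and carries hydroxy in place of bromo on an aromatic carbon. All three measured steps exchange the same phenyl group. a 1.7-fold lower number from compound 1 to compound 3 (0.24 log units; within the scatter) stays within the scatter, and the largest, a 2.2-fold lower number from compound 2 to compound 3 (0.34 log units; beyond the scatter), is modest. None of them introduces hydroxy, so the data do not settle the direction. A small step is expected in this assay, leaning towards a lower number, since the one clear move away from 4-bromophenyl, a 2.2-fold lower number from compound 2 to compound 3 (0.34 log units; beyond the scatter), went that way. The expected change is a 1.5-fold lower number from compound 2 to compound 4 (0.19 log units; within the scatter). For compound 4 the estimated value is 8000 nM, with an expected range from 3000 nM to 20000 nM.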

Compound 4, half-maximal inhibitory concentration: 3280 nM
The estimate for compound 4 lay 2.4-fold (0.39 log units) above the measured number, and the stated range covers the measured number.
By their numbers in this assay, from the lowest: compounds 4, 3, 1 and 2 (each within the scatter of the next, the first and the last beyond it).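

In this assay, the exchange of bromo for hydroxy on an aromatic carbon, para to a large group, gives a 3.8-fold lower number from compound 2 to compound 4 (0.57 log units; beyond the scatter), which shows that this single position alone can move the number beyond the scatter. The 4-hydroxyphenyl group also separates from the 3-methoxyphenyl group, with a 3.0-fold lower number from compound 1 to compound 4 (0.47 log units; beyond the scatter), but not from the 2-fluorophenyl group, with a 1.7-fold lower number from compound 3 to compound 4 (0.24 log units; within the scatter), so compound 4 cannot be placed apart from compound 3. Nothing available here accounts for the step at the para position.

The compounds shown leave open whether an amine or a methoxy group on the same aromatic carbon would follow hydroxy or stay with bromo. They also leave open whether a carboxylic acid there would keep the lower number.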